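Aryl exchange on the sulfonyl sulfur, compound 2 to 3

The compounds below may be only part of what the source reports. "The series", "measured", "known", "first", "only" and "open" are said of these compounds alone.

Measured so far:
Compound 1, `CCn1cc(C(=O)O)c(=O)c2cc(F)c(N3CCN(C(=N)NS(=O)(=O)c4ccc(C)cc4)CC3)cc21`; in a functional assay on HeLa cells (Homo sapiens) for antiproliferative activity, read by MTT assay, with a stated time of 72 h (on this read-out lower numbers stand for stronger inhibition and higher numbers for weaker inhibition), compound 1 gives 32 nM.
Compound 2, `N=C(NS(=O)(=O)c1ccccc1Cl)N1CCN(c2cc3c(cc2F)c(=O)c(C(=O)O)cn3C2CC2)CC1`; in this assay compound 2 gives 32 nM.

Compound 2 stands level with compound 1 at the digits recorded; the two values lie within the scatter of each other, so no order between them can be read. Among the compounds with values here, compounds 1 and 2 differ in more than one place, and no single step between them is available, so only their two values can be set side by side.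

Compound 3, `Cc1ccc(S(=O)(=O)NC(=N)N2CCN(c3cc4c(cc3F)c(=O)c(C(=O)O)cn4C3CC3)CC2)cc1`, has not yet been measured in this assay. It differs from compound 2 in one place: 4-methylphenyl in place of 2-chlorophenyl on a sulfonyl sulfur. The 4-methylphenyl that enters is the group compound 1 carries on its sulfonyl sulfur, so compound 3 joins the sulfonyl group of compound 1 to the remainder of compound 2.

Because compound 1 gives 32 nM with 4-methylphenyl on the sulfonyl sulfur, and compound 2 gives 32 nM with 2-chlorophenyl there, the exchange is expected to shift the number by no more than the scatter, in no particular direction. The expected step is no change at the digits printed from compound 2 to compound 3 (within the scatter). Compound 3 is therefore estimated at 32 nM, within a range from 16 nM to 64 nM.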

Compound 3, half-maximal inhibitory concentration: 32 nM
Compound 3: middle estimate and measured number agree at the digits printed, within the range that was stated.
By their numbers in this assay, from the lowest: compounds 1, 2 and 3 (each within the scatter of the next).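

In this assay, the exchange of 2-chlorophenyl for 4-methylphenyl on a sulfonyl sulfur reads as no change at the digits printed from compound 2 to compound 3 (within the scatter), so with cyclopropyl on the aromatic nitrogen this position accepts either aryl group with no readable shift, a statement the two earlier compounds could not support since they differ in more than one place. The second single-place comparison, cyclopropyl in place of ethyl on an aromatic nitrogen, reads as no change at the digits printed from compound 1 to compound 3 (within the scatter), which separates that change from the aryl exchange and shows it to be equally without a readable shift when 4-methylphenyl sits on the sulfonyl sulfur. No measurement at hand accounts for either flat step.

On these data alone, each change rests on a single pair, so it remains open whether the flat result would hold for a sulfonyl sulfur carrying a methyl group or a phenyl ring bearing an amine or a carboxylic acid. As far as these compounds go, it also remains open whether a longer chain, such as butyl, on the aromatic nitrogen would leave the number in the same place.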